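The source may report more compounds than this note shows. Statements on the series, on what has been measured and on what is new or still open speak of the compounds shown alone.

Compound 1, `Cc1cccnc1-c1cc2n(n1)CCN(C(=O)c1ccccc1)C2`: > 10000 nM (a limit of the assay, not a number)
Compound 2, `Cc1ccc(-c2cc3n(n2)CCN(C(=O)c2ccccc2)C3)nc1`: 244 nM
Compound 3, `O=C(c1ccccc1)N1CCn2nc(-c3ccc(F)cn3)cc2C1`: 164 nM

In a functional assay on HEK293 cells for negative allosteric modulation of metabotropic glutamate receptor 5 (Homo sapiens), read by calcium flux, with a stated time of 20 min (a lower number here means a stronger inhibitor, a higher number a weaker inhibitor), compound 3 holds the lowest of the two numbers shown, and compound 2 lies within the scatter of it: a 1.5-fold lower number from compound 2 to compound 3 (0.17 log units; within the scatter). Compound 1 reaches only the limit of this assay, as noted in the limit of > 10000 nM in this assay, at which 1 of the 3 values shown sits. Compound 4, `COc1cccc(C(=O)N2CCn3nc(-c4ccc(F)cn4)cc3C2)c1`, differs from compound 3 by methoxy in place of hydrogen on an aromatic carbon. Among the measured compounds shown here, the two large measured steps, an at least 40-fold lower number from compound 1 to compound 2 (1.61 log units; beyond the scatter) and an at least 60-fold lower number from compound 1 to compound 3 (1.78 log units; beyond the scatter), both concern the pyridin-2-yl group, not the phenyl where this change sits, so no measured step bears directly on it. With nothing pointing either way, no step beyond the scatter is expected: a 1.0-fold lower number from compound 3 to compound 4 (0.01 log units; within the scatter). Compound 4 is therefore estimated at 160 nM, within a range from 50 nM to 600 nM.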

Compound 4, half-maximal inhibitory concentration: 482 nM
The estimate for compound 4 lay 3.0-fold (0.48 log units) below the measured number; the measured number falls inside the stated range.
By their numbers in this assay, from the lowest: compounds 3, 2 and 4 (each within the scatter of the next, the first and the last beyond it). At a limit, above all of these: compound 1.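

Going from phenyl to 3-methoxyphenyl shows that this ring is not indifferent to substitution: methoxy in place of hydrogen gives a 2.9-fold higher number from compound 3 to compound 4 (0.47 log units; beyond the scatter). Among the compounds shown here, the other steps all lie on the pyridin-2-yl group, so this is the only measured change on the phenyl, and it weakens inhibition modestly without abolishing it. Nothing measured here gives a reason for this loss. Going by these compounds, whether a chlorine atom, a nitrile or an amine on this carbon would act like methoxy stays open. So does the effect of methoxy on the ring's other carbons.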